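Propargyl for Cyclopropylmethyl on a Xanthine-Type Scaffold

A few compounds are considered here, and "the series" means these few. Any claim that something is new, unique, unknown or untested is made for them only; others in the source may bear on it.

Of the compounds shown here, two have been measured in an assay on cell membranes for displacement of a labelled ligand from adenosine receptor A1 (Rattus norvegicus); a lower number here means a stronger inhibitor, a higher number a weaker inhibitor. Compound 1 `CC(C)Cn1c(=O)c2[nH]c(Cc3ccccc3)nc2n(Cc2ccco2)c1=O` gives 490 nM in this assay. Compound 2 `O=c1c2[nH]c(Cc3cccs3)nc2n(Cc2ccco2)c(=O)n1CC1CC1` gives 347 nM in this assay. These two numbers lie within the scatter of each other, so neither compound can be set above the other on the evidence at hand; compound 2 simply shows the lower of the two figures. Among the compounds with values here, compound 1 and compound 2 differ in two places at once, so no single step between them can be read.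

Compound 3 `C#CCn1c(=O)c2[nH]c(Cc3cccs3)nc2n(Cc2ccco2)c1=O` has not yet been measured. It differs from compound 2 in one place: ethynyl in place of cyclopropyl on a saturated chain carbon bound to an aromatic nitrogen. The shared core, the thiophene-bearing arm and the furan-bearing arm are kept. Within the data shown here, no measured pair in this set isolates such a change, so there is nothing to calibrate its size or direction. The step from compound 2 to compound 3 is therefore expected to be small, a 1.2-fold higher number from compound 2 to compound 3 (0.06 log units; within the scatter), and most likely within the scatter in either direction. On that basis compound 3 is estimated to give 400 nM in this assay, with a range from 150 nM to 1200 nM.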

Compound 3, inhibition constant: 219 nM
Estimate against measurement, compound 3: 1.8-fold (0.26 log units) above; the measured number falls inside the stated range.
By their numbers in this assay, from the lowest: compounds 3, 2 and 1 (each within the scatter of the next, the first and the last beyond it).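

Within the data shown here, the step of a 1.6-fold lower number from compound 2 to compound 3 (0.20 log units; within the scatter) in this assay is the first single-place comparison in this set, since compound 1 differs from compound 2 and from compound 3 in more than one place and its steps to them cannot be read. It shows that, on a saturated chain carbon bound to an aromatic nitrogen, cyclopropylmethyl can give way to propargyl, with the three-membered ring leaving and a triple bond entering, and the number stays within the scatter, so the two groups cannot be told apart here while the shared core, the thiophene-bearing arm and the furan-bearing arm are kept. No measurement in hand bears on why the two groups read alike.

From the compounds shown here alone, this is one pair on one pair of arms, so it remains open whether the same change would read alike with the arm that compound 1 carries in place of the thiophene-bearing arm. Going by these compounds, it is equally open how a plain propyl chain, a longer chain such as pentyl, or a chain ending in an amine or a carboxylic acid would read at this position.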